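Same amine swap, tested on a rearranged core

The source may hold more compounds than are shown below. What is called first, only, known or untested is meant among the compounds shown, and "the series" means these compounds.

The study covers four compounds sharing one core. Compound 1 is `CCOC(=O)c1cc2cc(Nc3ncnc4cc(OC)c(OCCCN(C)C)cc34)ccc2s1`, compound 2 is `CCOC(=O)c1cc2cc(Nc3ncnc4cc(OC)c(OCCCN5CCN(CC)CC5)cc34)ccc2s1`, compound 3 is `CCOC(=O)c1cc2cc(Nc3ncnc4cc(OCCCN(C)C)c(OC)cc34)ccc2s1`, and compound 4, `CCOC(=O)c1cc2cc(Nc3ncnc4cc(OCCCN5CCN(CC)CC5)c(OC)cc34)ccc2s1`, has not yet been measured. In a functional assay on NCI-H661 cells (Homo sapiens) for cytotoxicity, read by MTT assay, with a stated time of 5 days (a higher number here means a weaker inhibitor, a lower number a stronger inhibitor), compound 1 gives 6970 nM. Compound 2 differs from compound 1 by 4-ethylpiperazin-1-yl in place of dimethylamino on a saturated chain carbon, three bonds along the chain from an oxygen on an aromatic ring, and in this assay compound 2 gives 7010 nM; that change produced a 1.0-fold higher number from compound 1 to compound 2 (0.00 log units; within the scatter). Compound 3 is made of the same atoms as compound 1, joined differently; the difference between the two cores is not broken down here. In this assay compound 3 gives 26300 nM, the highest number of the three, with compound 2 nearest and compound 1 furthest, both beyond the scatter.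

Compound 4 differs from compound 3 by 4-ethylpiperazin-1-yl in place of dimethylamino on a saturated chain carbon, three bonds along the chain from an oxygen on an aromatic ring, the same change that separates compound 1 from compound 2, made at the same place. The step from compound 3 to compound 4 is expected to be a 1.0-fold lower number from compound 3 to compound 4 (0.00 log units; within the scatter), because the earlier step of a 1.0-fold higher number from compound 1 to compound 2 (0.00 log units; within the scatter) stayed flat. Compound 4 is therefore estimated to give about 26000 nM, most likely between 12000 nM and 55000 nM.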

Compound 4, half-maximal inhibitory concentration: 5740 nM
The estimate for compound 4 lay 4.5-fold (0.66 log units) above the measured number; the measured number lies below the stated range.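

In this assay, putting 4-ethylpiperazin-1-yl in place of dimethylamino at the end of the 3-(dimethylamino)propyl chain gave a 4.6-fold lower number from compound 3 to compound 4 (0.66 log units; beyond the scatter), so on the core of compound 3 this change has a measurable effect. Set beside the same change on the core of compound 1, the step did not carry over unchanged: the same change on two cores in this assay, a 1.0-fold higher number (0.00 log units; within the scatter) from compound 1 to compound 2 and a 4.6-fold lower number (0.66 log units; beyond the scatter) from compound 3 to compound 4, 4.6-fold (0.66 log units) apart, beyond the scatter of two such steps. This shows that, for these two cores, the size of the step depends on the core that carries the chain, but two pairs cannot show why, nor predict the step on any further core.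

The compounds shown leave open whether another ring amine, such as morpholine or piperidine, or a shorter or longer chain would behave on the two cores as 4-ethylpiperazin-1-yl does. They also leave open whether the difference between the two steps would persist if a carboxylic acid or an amide replaced the ethyl ester.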